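The source may hold more compounds than are shown below. What is called first, only, known or untested is meant among the compounds shown, and "the series" means these compounds.

Compounds measured so far in an ADME assay on MRC5 cells (Homo sapiens), read by MTT assay, with a stated time of 72 h (a lower number here means a stronger inhibitor, a higher number a weaker inhibitor), are these:
- compound 1 `CN(C)c1ncnc2c1c(-c1cc3ccccc3o1)cn2[C@@H]1O[C@H](CO)[C@@H](O)[C@H]1O` gives > 100000 nM as a limit
- compound 2 `Nc1nc(N)c2c(-c3ccsc3)cn([C@@H]3O[C@H](CO)[C@@H](O)[C@H]3O)c2n1` gives > 100000 nM as a limit
- compound 3 `COc1nc(N)nc2c1c(-c1ccoc1)cn2[C@@H]1O[C@H](CO)[C@@H](O)[C@H]1O` gives > 100000 nM as a limit

Compound 3 therefore has no numerical value, and its > 100000 nM is only a limit of the assay. Among the measured compounds shown here, the whole set stands at the limit of > 100000 nM in this assay, at which 3 of the 3 values shown sit, and offers no measured step between compounds from which to judge the size of a change.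

Compound 4 `COc1nc(N)nc2c1c(-c1ccsc1)cn2[C@@H]1O[C@H](CO)[C@@H](O)[C@H]1O` keeps the core of compound 3 and carries thiophen-3-yl in place of furan-3-yl on an aromatic carbon of the five-membered aromatic ring with 1 nitrogen. Compound 2 also bears thiophen-3-yl, and its > 100000 nM is likewise a limit, although it differs from compound 4 elsewhere on the shared core.

On this basis, no step beyond the usual scatter is expected in this assay, and no direction can be favoured. A reading at the limit is the most likely outcome, though a number just inside the range of the assay remains possible. The estimated change is a number no higher from compound 3 to compound 4 (the limit leaves the size open) and is expected to be negligible. For compound 4 the estimated value is 100000 nM with an expected range from 30000 nM to 100000 nM in this assay.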

Compound 4, half-maximal inhibitory concentration: > 100000 nM
Compound 4 gave a limit, no number; the forecaster's own chance of this, stated with the estimate: 80%; the middle value sits exactly at the limit.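

In this assay compound 4 gives > 100000 nM, which is a limit and not a number, so its steps from compound 3 and from compound 2 cannot be read. The compounds shown leave open whether any of them differ at all in this assay, where all share one reading: the limit of > 100000 nM in this assay, at which 4 of the 4 values shown sit.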